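Reversing the amide: from compound 3 to compound 4

The compounds below may be only part of what the source reports. "The series", "measured", "known", "first", "only" and "open" are said of these compounds alone.

Measured so far in a functional assay on DU-145 cells (Homo sapiens) for antiproliferative activity, read by sulforhodamine B assay, with a stated time of 3 days; on this read-out higher numbers stand for weaker inhibition of growth and lower numbers for stronger inhibition of growth:
compound 1, `O=C(NCCO)c1cccc(Nc2ncc(F)c(Nc3ccc(F)cc3)n2)c1`: 13400 nM
compound 2, `O=C(Nc1cccc(Nc2ncc(F)c(Nc3ccc(F)cc3)n2)c1)c1ccccc1`: > 10000 nM
compound 3, `O=C(Nc1ccccn1)c1cccc(Nc2ncc(F)c(Nc3ccc(F)cc3)n2)c1`: 15100 nM

In this assay compound 3 holds the highest of the two numbers read; the step of a 1.1-fold higher number from compound 1 to compound 3 (0.05 log units; within the scatter) lies within the scatter. The value of compound 2 is a limit of this assay (the limit of > 10000 nM in this assay, at which 1 of the 3 values shown sits), so the step that the limit leaves unreadable from compound 2 to compound 3 cannot be sized. Compound 4, `O=C(Nc1cccc(Nc2ncc(F)c(Nc3ccc(F)cc3)n2)c1)c1cnccn1`, differs from compound 3 as follows: ((pyrazin-2-yl)carbonyl)amino in place of (pyridin-2-yl)carbamoyl on an aromatic carbon. Among the measured compounds shown here, no measured step mirrors this change; the one readable step, a 1.1-fold higher number from compound 1 to compound 3 (0.05 log units; within the scatter), exchanged the group on the amide nitrogen without moving the number. Compound 4 is therefore expected to show a 1.0-fold lower number from compound 3 to compound 4 (0.00 log units; within the scatter), nothing beyond the scatter. Compound 4 is estimated at 15000 nM, in a range from 6000 nM to 40000 nM.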

Compound 4, concentration for 50% growth inhibition: 26400 nM
Compound 4: middle estimate off by 1.8-fold (0.25 log units), on the low side, and the stated range covers the measured number.
By their numbers in this assay, from the lowest: compounds 1, 3 and 4 (each within the scatter of the next).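

In this assay, reversing the amide at this position and placing a pyrazin-2-yl ring on the carbonyl gives a 1.7-fold higher number from compound 3 to compound 4 (0.24 log units; within the scatter), while exchanging the (2-hydroxyethyl)carbamoyl group for the same ((pyrazin-2-yl)carbonyl)amino group gives a 2.0-fold higher number from compound 1 to compound 4 (0.29 log units; within the scatter). Amide direction is thus a new variation at this position, and it does not move the number beyond the scatter. Compound 2 carries a limit, so its step to compound 4 cannot be read: the limit of > 10000 nM in this assay, at which 1 of the 4 values shown sits.

This change reversed the amide and exchanged the ring at once, and the compounds shown do not separate the two. On these data alone, whether an amine or a carboxylic acid at this position would shift the number beyond the scatter remains open.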